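The compounds below may be only part of what the source reports. "The series", "measured", "known", "first", "only" and "open" are said of these compounds alone.

Compound 1, `CCCCC(=O)Oc1ccc(/C=C/C(=O)c2c(OC)cc3c(c2O)CCC(C)(C)O3)cc1`: in an assay on HEK293T cells for inhibition of nuclear factor NF-kappa-B complex (Homo sapiens), read by a luciferase reporter (a lower number here means a stronger inhibitor, a higher number a weaker inhibitor), compound 1 gives > 30000 nM, which is a limit of the assay and not a number.
Compound 2, `COc1cc2c(c(O)c1C(=O)/C=C/c1ccc(OC(=O)c3ccccc3F)cc1)CCC(C)(C)O2`: in this assay compound 2 gives > 30000 nM, again a limit rather than a number.

For the measured compounds named here, the one measured step, a step that the two limits leave unreadable from compound 1 to compound 2, cannot be sized because both of its ends sit at the limit of > 30000 nM in this assay, at which 2 of the 2 values shown sit. Compound 2 therefore stands only at a limit in this assay, and no order among the measured compounds can be read.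

Compound 3, `C=CC(=O)Oc1ccc(/C=C/C(=O)c2c(OC)cc3c(c2O)CCC(C)(C)O3)cc1`, differs from compound 2 in one place: vinyl in place of 2-fluorophenyl on a carbonyl carbon. Going by the values given here, no measured step covers this change, and the single step that is known is itself unreadable, so nothing beyond the scatter can be expected in either direction. Compound 3 is estimated to remain at the limit in this assay, at 30000 nM, within 10000 nM to 100000 nM, so that the expected step from compound 2 to compound 3 is a number no higher from compound 2 to compound 3 (the limit leaves the size open).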

Compound 3, half-maximal inhibitory concentration: 8990 nM
Estimate against measurement, compound 3: 3.3-fold (0.52 log units) above; measured number outside the range, below it.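

In this assay, vinyl in place of 2-fluorophenyl on a carbonyl carbon gives an at least 3.3-fold lower number from compound 2 to compound 3 (0.52 log units; beyond the scatter), and vinyl in place of butyl gives an at least 3.3-fold lower number from compound 1 to compound 3 (0.52 log units; beyond the scatter). For the compounds shown here, this position therefore does respond to the group it carries, which the two earlier compounds could not show, and compound 3 gives the first reading here that is a number and not a limit. The true sizes of these steps stay open, and the step between the two earlier compounds cannot be read, because those compounds give only a limit: the limit of > 30000 nM in this assay, at which 2 of the 3 values shown sit.

The compounds shown leave open whether the lower number follows the double bond of vinyl or only its two carbons, a question on which ethyl, with two carbons and no double bond, would bear. On these data alone, how a longer chain carrying such a double bond, or an amine at the end of the vinyl group, would read also remains open.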